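The source may report more compounds than this note shows. Statements on the series, on what has been measured and on what is new or still open speak of the compounds shown alone.

Measured in a functional assay on PC-3 cells (Homo sapiens) for inhibition, read by sulforhodamine B assay, with a stated time of 48 h; a higher number here means a weaker inhibitor of growth, a lower number a stronger inhibitor of growth:
- Compound 1 `CC1(/C=C/c2ccccc2)C=CC(=O)O1`: 86900 nM
- Compound 2 `CC1(/C=C/c2ccccc2C(F)(F)F)C=CC(=O)O1`: 17900 nM

Of these two compounds, compound 1 has the higher number, at 86900 nM, which makes it the weaker inhibitor of growth and leaves room for improvement. Compound 3 `CC1(/C=C/c2ccc(C(F)(F)F)cc2)C=CC(=O)O1` has not yet been measured. It differs from compound 1 by trifluoromethyl in place of hydrogen on an aromatic carbon, para to a group of 9 heavy atoms: trifluoromethyl in place of hydrogen on an aromatic carbon.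

Going by the values given here, only one measured step bears on this change, the one that puts the same group onto another carbon of the aromatic ring. That step is a 4.9-fold lower number from compound 1 to compound 2 (0.69 log units; beyond the scatter), modest in size but beyond the scatter. A single step cannot show how much the position of the group matters, so it serves only as a rough guide. A step in the same direction is therefore expected, perhaps somewhat smaller, and the range is kept wide.

The estimated change in this assay is a 2.9-fold lower number from compound 1 to compound 3 (0.46 log units; beyond the scatter). The expected value for compound 3 is 30000 nM, with an estimated range from 12000 nM to 70000 nM.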

Compound 3, concentration for total growth inhibition: 13100 nM
Beside the measured number, compound 3's estimate is 2.3-fold (0.36 log units) above it; low and high end bracket the measured number.
By their numbers in this assay, from the lowest: compounds 3 and 2 (each within the scatter of the next); then compound 1.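

In this assay, trifluoromethyl in place of hydrogen on an aromatic carbon, para to a group of 9 heavy atoms, gives a 6.6-fold lower number from compound 1 to compound 3 (0.82 log units; beyond the scatter), so the gain seen with compound 2 is not confined to one carbon of the ring. Compound 3 and compound 2 lie within the scatter of each other, which means these numbers do not separate the two placements of the group: moving it around the ring has shown no clear effect so far, although two placements are a small sample. Nothing measured here explains why adding this group lowers the number.

As far as these compounds go, it remains open whether the gain belongs to trifluoromethyl in particular or would also appear with another group on the same carbon, such as a single fluorine atom, a chlorine atom, a methoxy group or an amine. From the compounds shown here alone, it is equally open whether the gain would persist on the other carbons of the ring, or whether two trifluoromethyl groups on one ring would lower the number further.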